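From a Cyano Group to an Ethoxymethyl Group

A few compounds are considered here, and "the series" means these few. Any claim that something is new, unique, unknown or untested is made for them only; others in the source may bear on it.

In a functional assay (trachea) with Cavia porcellus as the target (a lower number here means that less compound is needed, a higher number that more compound is needed for the effect), compound 1 (`CCCn1c(=O)n(CCC(N)=O)c(=O)c2[nH]cnc21`) gives 13100 nM and compound 2 (`CCCn1c(=O)n(CCCN(C)C)c(=O)c2[nH]cnc21`) gives 20500 nM in the same test. Compound 3 (`CCCn1c(=O)n(C)c(=O)c2c1ncn2CC#N`) gives 35300 nM there. Its value lies within the scatter of that of compound 2, while it stands beyond the scatter from that of compound 1, on the side of more compound being needed.

Compound 4 (`CCCn1c(=O)n(C)c(=O)c2c1ncn2CCOCC`) has ethoxymethyl in place of cyano on a saturated chain carbon bound to an aromatic nitrogen. For the measured compounds named here, no measured step covers this exchange. The only one available, a 1.6-fold higher number from compound 1 to compound 2 (0.19 log units; within the scatter) for a different exchange, concerns a chain carbon two bonds along the chain from an aromatic nitrogen, and it offers only weak guidance. It gives no reason to expect a change beyond the scatter in this assay here. The expected step is a 1.2-fold lower number from compound 3 to compound 4 (0.07 log units; within the scatter) and thus no real shift. Compound 4 is estimated at 30000 nM with an expected range from 11000 nM to 80000 nM in this test.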

Compound 4, half-maximal effective concentration: 4600 nM
Estimate against measurement, compound 4: 6.5-fold (0.81 log units) above; measured number outside the range, below it.
By their numbers in this assay, from the lowest: compound 4; then compounds 1, 2 and 3 (each within the scatter of the next, the first and the last beyond it).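

In this assay the exchange of cyano for ethoxymethyl on a saturated chain carbon bound to an aromatic nitrogen gives a 7.7-fold lower number from compound 3 to compound 4 (0.89 log units; beyond the scatter) and so lies beyond the scatter. For the compounds shown here, this shows that the number in this test responds to the group carried at this place, something the earlier compounds could not show: their only step concerned a different exchange at a different chain carbon and stayed within the scatter. Nothing shown accounts for the size of this step.

The compounds shown do not separate the contribution of the oxygen of the ethoxymethyl group from that of its carbons, which a plain butyl chain at this place could address. Going by these compounds, whether an amine or a carboxylic acid there would fall nearer to cyano or to ethoxymethyl also remains open.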